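The source may report more compounds than this note shows. Statements on the series, on what has been measured and on what is new or still open speak of the compounds shown alone.

Compound 2, with the structure `Cc1ccc(S(=O)(=O)N(Cc2nnc(Cc3ccc(F)cc3)o2)c2cccc(Cl)c2C)cc1`, gives 501 nM in a functional assay on CHO cells for antagonist activity at prostaglandin E2 receptor EP1 subtype (Homo sapiens), read by FLIPR and calcium flux; on this read-out lower numbers stand for stronger inhibition and higher numbers for weaker inhibition. Among the two compounds measured there it carries the highest number, that is, the weaker inhibition. Compound 1, whose structure is `CCOc1ccc(Cc2nnc(CN(c3ccccc3CC)S(=O)(=O)c3ccc(C)cc3)o2)cc1`, gives 39.8 nM in this assay; the two compounds differ in more than one place, so the two values can only be set side by side, and they stand apart by more than the usual scatter.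

Compound 3, with the structure `Cc1ccc(S(=O)(=O)N(Cc2nnc(Cc3ccc(Cl)cc3Cl)o2)c2cccc(Cl)c2C)cc1`, has not yet been measured in this assay. It differs from compound 2 in one place: 2,4-dichlorophenyl in place of 4-fluorophenyl on a saturated chain carbon bound to an aromatic carbon. Going by the values given here, no measured pair shows this exchange, so its effect on the inhibition constant is not known from the data at hand. One can only expect that the step from compound 2 to compound 3 will be small, with no clear direction beyond the scatter, roughly a 1.6-fold lower number from compound 2 to compound 3 (0.19 log units; within the scatter). On that basis compound 3 is estimated to give about 320 nM in this assay, with a likely range from 80 nM to 1300 nM.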

Compound 3, inhibition constant: 1000 nM
Estimate against measurement, compound 3: 3.1-fold (0.49 log units) below; measured number inside the range.
By their numbers in this assay, from the lowest: compound 1; then compounds 2 and 3 (each within the scatter of the next).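

In this assay, 2,4-dichlorophenyl in place of 4-fluorophenyl on a saturated chain carbon bound to an aromatic carbon gives a 2.0-fold higher number from compound 2 to compound 3 (0.30 log units; within the scatter). Going by these compounds alone, this is the first step that can be read at a single place, and it shows that, with the rest of compound 2 held fixed, two chlorine atoms can replace one fluorine atom on this aromatic ring, and the heavy-atom count of the group can go from 7 to 8, without a change that stands clear of the scatter. Nothing at hand explains the size of this step, which rests on this one pair alone.

The compounds shown leave open whether an amine or a carboxylic acid on this aromatic ring, or a longer chain at the saturated chain carbon, would move the number beyond the scatter. On these data alone, compound 1 differs from compound 2 in more than one place, so the part of their gap that belongs to this position also remains open.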